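Swapping the Indole on a Shared Core

The compounds below may be only part of what the source reports. "The series", "measured", "known", "first", "only" and "open" are said of these compounds alone.

Measured compounds:
compound 1 `COc1ccc(-c2cc3nccc(-c4cc(OC)c(OC)c(OC)c4)n3n2)cc1F`: 183 nM
compound 2 `COc1cc(-c2ccnc3cc(-c4c[nH]c5ccccc45)nn23)cc(OC)c1OC`: 85 nM

For the measured compounds named here, in a functional assay on MCF7 cells (Homo sapiens) for inhibition, read by CCK-8 assay, with a stated time of 48 h (on this read-out higher numbers stand for weaker inhibition and lower numbers for stronger inhibition), compound 2 gives 85 nM, the lowest of the two numbers; its only neighbour, compound 1, gives 183 nM, and the step of a 2.2-fold lower number from compound 1 to compound 2 (0.33 log units; beyond the scatter) was modest. Compound 3 `COc1cc(-c2ccnc3cc(-c4ccc5ccn(C)c5c4)nn23)cc(OC)c1OC` differs from compound 2 by 1-methyl-1H-indol-6-yl in place of 1H-indol-3-yl on an aromatic carbon. Going by the values given here, no measured step involves this change; the single step seen, a 2.2-fold lower number from compound 1 to compound 2 (0.33 log units; beyond the scatter), concerns a different group on an aromatic carbon, so the expected change is within the scatter or modest at most. Compound 3 is therefore estimated at 110 nM, ranging from 40 nM to 300 nM, an expected step of a 1.3-fold higher number from compound 2 to compound 3 (0.11 log units; within the scatter).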

Compound 3, half-maximal inhibitory concentration: 74 nM
Estimate against measurement, compound 3: 1.5-fold (0.17 log units) above, and the stated range covers the measured number.
By their numbers in this assay, from the lowest: compounds 3 and 2 (each within the scatter of the next); then compound 1.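

At this position, on the aromatic carbon of the five-membered ring, the hydrogen-bond donor of 1H-indol-3-yl is gone in 1-methyl-1H-indol-6-yl, yet this assay shows a 1.1-fold lower number from compound 2 to compound 3 (0.06 log units; within the scatter) and so no change. Against 3-fluoro-4-methoxyphenyl, the new indole also gives a 2.5-fold lower number from compound 1 to compound 3 (0.39 log units; beyond the scatter) and thus keeps the modest edge that 1H-indol-3-yl had. Nothing available gives a cause for these steps.

Still open, as far as these compounds go, is whether the position keeps this level with an amine, a carboxylic acid or a longer chain in place of the indole. The separate contributions of the methyl on the indole nitrogen and of the change from 3-yl to 6-yl also remain unresolved.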